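Benzyl in Place of Methyl on Selenium

The source may report more compounds than this note shows. Statements on the series, on what has been measured and on what is new or still open speak of the compounds shown alone.

Compound 1, `C[Se]/C(=N\C(=O)c1ccco1)NC(=O)c1ccco1`: in a functional assay on PC-3 cells (Homo sapiens) for cytotoxicity, read by MTT assay, with a stated time of 72 h (a lower number here means a stronger inhibitor of growth, a higher number a weaker inhibitor of growth), compound 1 gives 56700 nM.
Compound 2, `C[Se]/C(=N\C(=O)c1ccno1)NC(=O)c1ccno1`: in this assay compound 2 gives 39300 nM.

Of the two measured compounds, compound 1 carries the higher number, but the value of compound 2 lies within the usual scatter of it, so the two cannot be told apart on these data. Compound 3, `O=C(/N=C(/NC(=O)c1ccco1)[Se]Cc1ccccc1)c1ccco1`, keeps the whole of compound 1 and differs from it in one place: phenyl in place of hydrogen on a saturated chain carbon bound to a selenium atom. Going by the values given here, no measured pair shows what this kind of change does in this assay , so there is nothing to lean on beyond the two values above. The step of a 1.4-fold lower number from compound 1 to compound 3 (0.15 log units; within the scatter) is therefore expected to stay small, most likely not beyond the scatter, with a slight lean toward a lower number. Compound 3 is estimated at 40000 nM, with a plausible range from 15000 nM to 110000 nM.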

Compound 3, concentration for total growth inhibition: 57600 nM
Beside the measured number, compound 3's estimate is 1.4-fold (0.16 log units) below it; the range from low to high includes it.
By their numbers in this assay, from the lowest: compounds 2, 1 and 3 (each within the scatter of the next).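

Going from methyl to benzyl in this assay gives a 1.0-fold higher number from compound 1 to compound 3 (0.01 log units; within the scatter), the first measured pair for this kind of change. On this pair, a phenyl on a saturated chain carbon bound to a selenium atom, with its six-membered aromatic ring of carbon only, leaves compound 3 indistinguishable from compound 1 in this read-out, so a substituent of this size is tolerated here without a detectable gain or loss in growth inhibition. Nothing available helps to explain this result.

This single pair cannot show whether the same holds when benzyl is placed on the core of compound 2. It also leaves open what a different group at this place would do, such as a longer chain of carbons or one ending in an amine or a carboxylic acid.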